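Phthalimide-Triazole Thioethers Tested for Cytotoxicity on Prostate Cancer Cells

The compounds below may be only part of what the source reports. "The series", "measured", "known", "first", "only" and "open" are said of these compounds alone.

Compound 1 `C#CCSc1nnc(C)n1N1C(=O)c2ccccc2C1=O` gives > 200000 nM in a functional assay on PC-3M cells (Homo sapiens) for cytotoxicity, read by MTT assay, with a stated time of 48 h (on this read-out higher numbers stand for weaker inhibition and lower numbers for stronger inhibition), a limit of the assay.
Compound 2 `Cc1nnc(SCc2ccccc2Cl)n1N1C(=O)c2ccccc2C1=O` gives > 200000 nM in this assay, a limit.
Compound 3 `COc1cc(-c2nnc(SCc3ccccc3Cl)n2N2C(=O)c3ccccc3C2=O)cc(OC)c1OC` gives > 200000 nM in this assay, a limit.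

All three measured compounds sit at a limit of this assay, so none of them yields a number. The change from compound 2 to compound 1 is ethynyl in place of 2-chlorophenyl on a saturated chain carbon bound to a sulfur; its step, a step that the two limits leave unreadable from compound 2 to compound 1, cannot be read because of the limit of > 200000 nM in this assay, at which 3 of the 3 values shown sit. The cores of compound 2 and compound 3 differ by 3,4,5-trimethoxyphenyl in place of methyl on an aromatic carbon, and that step, a step that the two limits leave unreadable from compound 2 to compound 3, is equally unreadable because of the limit of > 200000 nM in this assay, at which 3 of the 3 values shown sit.

Compound 4 `C#CCSc1nnc(-c2cc(OC)c(OC)c(OC)c2)n1N1C(=O)c2ccccc2C1=O` is not yet measured. It differs from compound 3 by ethynyl in place of 2-chlorophenyl on a saturated chain carbon bound to a sulfur, the same change that separates compound 2 from compound 1, made on the core of compound 3. Since compound 3 gives > 200000 nM, a limit, and compound 1 likewise gives > 200000 nM, a limit, the step of a number no higher from compound 3 to compound 4 (the limit leaves the size open) is expected to be unreadable in the same way. Compound 4 is therefore estimated at 200000 nM, with a range from 100000 nM to 400000 nM, and most likely to be reported as a limit rather than a number.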

Compound 4, half-maximal inhibitory concentration: > 200000 nM
Compound 4 was reported as a limit; the forecaster's own chance of this, stated with the estimate: 85%; the middle value sits exactly at the limit.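

Going by these compounds alone, compound 3 and compound 4 yield no new readable step, because neither gives a number: the limit of > 200000 nM in this assay, at which 4 of the 4 values shown sit. The compounds shown leave open whether ethynyl in place of 2-chlorophenyl, or 3,4,5-trimethoxyphenyl in place of methyl, changes the result in this assay at all, and at what concentration any of the four compounds would reach half-maximal inhibition.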